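The source may report more compounds than this note shows. Statements on the series, on what has been measured and on what is new or still open speak of the compounds shown alone.

Values in a physicochemical assay for solubility, read by nephelometry, measured as kinetic solubility, with a stated time of 30 min; a higher number here means a more soluble compound, a lower number a less soluble compound:
- Compound 1 `CC(C)(O)CN1CCC(Oc2ccc([C@H]3CC[C@]4(CC3)OOC3(O4)C4CC5CC(C4)CC3C5)cc2)CC1`: 1.6 ug/mL
- Compound 2 `c1cc([C@H]2CC[C@]3(CC2)OOC2(O3)C3CC4CC(C3)CC2C4)ccc1OC1CCNCC1`: > 100 ug/mL
- Compound 3 `c1cc([C@H]2CC[C@]3(CC2)OOC2(O3)C3CC4CC(C3)CC2C4)ccc1OCC1CCNCC1`: 12.5 ug/mL

Compound 2 reads > 100 ug/mL and this is a limit, not a number. Of the two actual numbers, compound 3 has the higher, as a 7.8-fold higher number from compound 1 to compound 3 (0.89 log units; beyond the scatter) shows.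

Compound 4 `N[C@H]1CC[C@@H](Oc2ccc([C@H]3CC[C@]4(CC3)OOC3(O4)C4CC5CC(C4)CC3C5)cc2)CC1` has 4-aminocyclohexyl in place of (piperidin-4-yl)methyl on an oxygen on an aromatic ring.

The measured change at that place, an at least 8.0-fold lower number from compound 2 to compound 3 (0.90 log units; beyond the scatter), was at least modest. The ring of compound 4 sits on the oxygen without the added carbon, so reversing that step points upward. The large at least 62-fold higher number from compound 1 to compound 2 (1.79 log units; beyond the scatter) concerns an amine nitrogen and bears only indirectly.

A modest rise is expected, estimated as a 2.4-fold higher number from compound 3 to compound 4 (0.38 log units; beyond the scatter). For compound 4 the estimated value is 30 ug/mL, with an expected range of 8 ug/mL to 100 ug/mL.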

Compound 4, solubility: 25 ug/mL
The estimate for compound 4 lay 1.2-fold (0.08 log units) above the measured number, and the stated range covers the measured number.
By their numbers in this assay, from the lowest: compound 1; then compounds 3 and 4 (each within the scatter of the next). At a limit, above all of these: compound 2.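

In this assay, 4-aminocyclohexyl in place of (piperidin-4-yl)methyl gives a 2.0-fold higher number from compound 3 to compound 4 (0.30 log units; within the scatter), so on this oxygen a ring of carbon only carrying the amine does not separate from the piperidine group. Against piperidin-4-yl, the same group gives an at least 4.0-fold lower number from compound 2 to compound 4 (0.60 log units; beyond the scatter), a step read from a limit. Compound 4 also stands clear of the hydroxylated piperidine, with a 16-fold higher number from compound 1 to compound 4 (1.19 log units; beyond the scatter).

As far as these compounds go, compound 2 gives a limit, not a number, so its true distance from the others stays open: the limit of > 100 ug/mL in this assay, at which 1 of the 4 values shown sits. How a morpholine or a carboxylic acid on this oxygen would read also remains open.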